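This account rests on a few compounds, and the source may have more. Where it says the series, first, only, none or still open, it means among the compounds named here.

Among the compounds with values here, compound 3 `Cc1c(OCCCCOc2ccc(C(=O)O)cc2F)ccc(C(=O)CC2CCCC2)c1O` is one of three compounds measured in an assay on HEK293 cells for positive allosteric modulation of metabotropic glutamate receptor 3 (Rattus norvegicus), read by thallium flux, with a stated time of 2.5 min; on this read-out higher numbers stand for an effect only at larger amounts of compound and lower numbers for an effect already at smaller amounts. Its value is a limit of the assay, and in this assay compound 3 gives > 10000 nM. Compound 1 `Cc1c(OCCCCOc2ccc(C(=O)O)cc2)ccc(C(=O)CC2CCCC2)c1O` also reaches only a limit, and in this assay compound 1 gives > 10000 nM. Compound 2 `Cc1c(OCCCCOCOc2ccc(C(=O)O)cc2)ccc(C(=O)CC2CCCC2)c1O` alone has a number: in this assay compound 2 gives 1910 nM. Two of the three values thus sit at the limit of > 10000 nM in this assay, at which 2 of the 3 values shown sit, so compound 3 stands where most of this small set stands, with no number to place it more closely.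

Compound 4 `Cc1c(OCCCCOc2ccc(C(=O)O)cc2Cl)ccc(C(=O)CC2CCCC2)c1O` differs from compound 3 by chloro in place of fluoro on an aromatic carbon. Within the data shown here, of the measured steps, only the one from compound 1 to compound 3 touches the same aromatic carbon, and a step that the two limits leave unreadable from compound 1 to compound 3. The steps of an at least 5.2-fold lower number from compound 1 to compound 2 (0.71 log units; beyond the scatter) and an at least 5.2-fold higher number from compound 2 to compound 3 (0.71 log units; beyond the scatter) concern the link to the 4-carboxyphenyl group, not the halogen, so none bears directly on this swap. With compound 3 at the limit and no readable step for the halogen, the expected change in this assay is a step that the limit leaves unreadable from compound 3 to compound 4, with compound 4 most likely remaining at the limit. Compound 4 is therefore estimated at 15000 nM, between 5000 nM and 50000 nM.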

Compound 4, half-maximal effective concentration: > 10000 nM
Compound 4: a limit, no number (the forecaster's own chance of this, stated with the estimate: 75%); the middle value is on the limit's open side.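

In this assay, compound 4 gives > 10000 nM, which is a limit of the assay and not a number. Within the data shown here, with chloro on this aromatic carbon, ortho to a large group and meta to a carboxy group, hydrogen, fluoro and chloro have now all been seen here without a number, and the steps among compound 1, compound 3 and compound 4 cannot be read: the limit of > 10000 nM in this assay, at which 3 of the 4 values shown sit. The one new step that can be read is an at least 5.2-fold higher number from compound 2 to compound 4 (0.71 log units; beyond the scatter), which leaves compound 2, with its (4-carboxyphenoxy)methyl group, the only one of the four with a number.

Going by these compounds, whether fluoro and chloro differ at all on this carbon stays open. So does what a methoxy group or a nitrile would do there, or what chloro would do on the aromatic ring of compound 2.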